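Propoxy in Place of Benzylamino: Cytotoxicity Expected Unchanged

A few compounds are considered here, and "the series" means these few. Any claim that something is new, unique, unknown or untested is made for them only; others in the source may bear on it.

Compound 1 `Nc1nc(NCc2ccccc2)c2ncn(/C=C3/CC3(CO)CO)c2n1` was examined in an ADME assay on CCRF-HSB-2 cells (Homo sapiens) for cytotoxicity, with a stated time of 7 days; a higher number here means that more compound is tolerated, a lower number that less compound is tolerated. In this assay compound 1 gives > 20000 nM, which is a limit of the assay and not a number. Two close relatives share its core. Compound 2 `Nc1nc2c(ncn2/C=C2/CC2(CO)CO)c(=O)[nH]1` gives > 20000 nM in this assay, again only a limit. Compound 3 `Nc1nc(NC2CCCCC2)c2ncn(/C=C3/CC3(CO)CO)c2n1` gives > 20000 nM in this assay, also a limit. The step from compound 1 to compound 3 is accordingly a step that the two limits leave unreadable from compound 1 to compound 3. What the three results together show is the limit of > 20000 nM in this assay, at which 3 of the 3 values shown sit.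

Compound 4 `CCCOc1nc(N)nc2c1ncn2/C=C1/CC1(CO)CO` is compound 1 with a change at one place: propoxy in place of benzylamino on an aromatic carbon. Among the measured compounds shown here, no measured step has a readable size, so none of them supplies a direction or a magnitude for this change; the one thing the earlier results offer is the limit of > 20000 nM in this assay, at which 3 of the 3 values shown sit. The expectation for compound 4 is that it, too, sits at the limit, so the estimated step that the limit leaves unreadable from compound 1 to compound 4 is none beyond the scatter. Compound 4 is therefore estimated at 25000 nM, with a range from 8000 nM to 80000 nM.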

Compound 4, half-maximal cytotoxic concentration: > 20000 nM
Compound 4 gave a limit, no number (the forecaster's own chance of this, stated with the estimate: 85%); the middle value is on the limit's open side.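

The steps from compound 1 and from compound 3 to compound 4 cannot be read, since each of these results is a limit and not a number: the limit of > 20000 nM in this assay, at which 4 of the 4 values shown sit.

The compounds shown leave open how the groups on the shared core would rank in this assay.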